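Fluorine Added to the Methoxyphenyl Amide

The source may hold more compounds than are shown below. What is called first, only, known or untested is meant among the compounds shown, and "the series" means these compounds.

Measured compounds:
Compound 1, `O=C(NC1CCN(Cc2ccc3ccccc3c2)CC1)c1ccccc1` — 347 nM
Compound 2, `COc1cccc(C(=O)NC2CCN(Cc3ccc4ccccc4c3)CC2)c1` — 29 nM

Of the compounds shown here, two have been measured in an assay on isolated protein for binding affinity to melanin-concentrating hormone receptor 1 (Homo sapiens); a lower number here means a stronger inhibitor, a higher number a weaker inhibitor. Compound 1 gives 347 nM in this assay. Compound 2 differs from it only in a methoxy in place of hydrogen on an aromatic carbon, and compound 2 gives 29 nM, which is the lowest of the two numbers; the step of a 12-fold lower number from compound 1 to compound 2 (1.08 log units; beyond the scatter) is large and well beyond the scatter. Compound 2 therefore stands at the stronger end of what has been seen so far.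

Compound 3, `COc1cc(C(=O)NC2CCN(Cc3ccc4ccccc4c3)CC2)ccc1F`, is not yet measured. It differs from compound 2 in a single place: fluoro in place of hydrogen on an aromatic carbon. Going by the values given here, no measured step here shows what a fluoro in place of hydrogen does on this aromatic ring, so the only guide is the methoxy-bearing compound 2 itself. A small, single-atom change of this kind is expected to leave compound 2's number roughly where it is, so the step of a 1.2-fold lower number from compound 2 to compound 3 (0.06 log units; within the scatter) is expected to lie within the scatter. Compound 3 is accordingly estimated at 25 nM, with a range of 8 nM to 80 nM.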

Compound 3, inhibition constant: 13 nM
Compound 3: the middle estimate sits 1.9-fold (0.28 log units) above what was measured; the range from low to high includes it.
By their numbers in this assay, from the lowest: compound 3; then compound 2; then compound 1.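

In this assay the place ortho to a methoxy group and para to a large group takes a fluoro with a further gain, a 2.2-fold lower number from compound 2 to compound 3 (0.35 log units; beyond the scatter) and so a modest step that lies beyond the scatter. Until now only the methoxy had been seen to move the number on this ring, and this result shows that a second small group can lower it further when the methoxy is already present. Taken whole, the change from 3-methoxyphenyl's parent phenyl to 4-fluoro-3-methoxyphenyl gives a 27-fold lower number from compound 1 to compound 3 (1.43 log units; beyond the scatter) and most of that size was already there with the methoxy alone, as a 12-fold lower number from compound 1 to compound 2 (1.08 log units; beyond the scatter) shows, while no measurement given here explains why either group lowers the number.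

The compounds shown leave open whether a fluoro on the phenyl ring would lower the number without the methoxy, and whether a chloro, a methyl or a nitrile in the fluoro's place would do the same. They also leave open how an ethoxy or a hydroxy would read in place of the methoxy alongside the fluoro.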